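Chalcone series: aryl exchange toward 4-methylphenyl

The compounds below may be only part of what the source reports. "The series", "measured", "known", "first", "only" and "open" are said of these compounds alone.

Compound 1 `COc1ccc(/C=C/C(=O)c2ccc(OCCn3cc(CN4C(=O)/C=C/C(C)(C)C/C=C(\C)CC/C=C/4C)nn3)cc2O)cc1` gives 1.67 ug/mL in a functional assay on Lu cells (Homo sapiens) for antiproliferative activity; on this read-out higher numbers stand for weaker inhibition and lower numbers for stronger inhibition. Compound 2 `COc1cc(/C=C/C(=O)c2ccc(OCCn3cc(CN4C(=O)/C=C/C(C)(C)C/C=C(\C)CC/C=C/4C)nn3)cc2O)cc(OC)c1OC` gives 1.28 ug/mL in this assay, the lowest of the two numbers measured, with compound 1 nearest; the step of a 1.3-fold lower number from compound 1 to compound 2 (0.12 log units; within the scatter) separates them. On these data alone, compound 3 `C/C1=C\CC(C)(C)/C=C/C(=O)N(Cc2cn(CCOc3ccc(C(=O)/C=C/c4ccc(C)cc4)c(O)c3)nn2)/C(C)=C/CC1` is untested in this assay and differs from compound 2 as follows: 4-methylphenyl in place of 3,4,5-trimethoxyphenyl on a double-bonded chain carbon bound to a double-bonded chain carbon. Among the measured compounds shown here, the only measured step that bears on this change is the exchange of aryl groups at the same place, a 1.3-fold lower number from compound 1 to compound 2 (0.12 log units; within the scatter), which did not move the read-out beyond the scatter. For the measured compounds named here, no measured step leads to an aryl group with no hydrogen-bond acceptors, so the present change goes further than anything measured. On this basis the estimated step is a 1.4-fold higher number from compound 2 to compound 3 (0.15 log units; within the scatter), expected to stay small with a slight drift toward a higher number. For compound 3 the expected value is 1.8 ug/mL, with a range from 0.8 ug/mL to 4 ug/mL.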

Compound 3, half-maximal inhibitory concentration: 0.91 ug/mL
The estimate for compound 3 lay 2.0-fold (0.30 log units) above the measured number, within the range that was stated.
By their numbers in this assay, from the lowest: compounds 3, 2 and 1 (each within the scatter of the next).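

In this assay, among the compounds shown here, the first aryl group without hydrogen-bond acceptors at this place, 4-methylphenyl, leaves the read-out within the scatter of the 3,4,5-trimethoxyphenyl compound despite the drop from 12 heavy atoms to 7, with a 1.4-fold lower number from compound 2 to compound 3 (0.15 log units; within the scatter). The single exchange of methyl in place of methoxy on an aromatic carbon also stays within the scatter, with a 1.8-fold lower number from compound 1 to compound 3 (0.26 log units; within the scatter), so neither methoxy nor hydrogen-bond acceptors on this aryl group are shown to be needed for the activity seen here. No measurement bearing on the cause of these small steps is available.

On these data alone, whether any aryl group at this place can move the read-out beyond the scatter remains open. An amine or a carboxylic acid on the aromatic ring, or a longer chain in place of methyl, would test this.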